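Changing the Group on Nitrogen in Compound 2

The source may hold more compounds than are shown below. What is called first, only, known or untested is meant among the compounds shown, and "the series" means these compounds.

In a functional assay on DU-145 cells (Homo sapiens) for cytotoxicity, read by trypan blue exclusion, with a stated time of 96 h (a lower number here means a stronger inhibitor, a higher number a weaker inhibitor), compound 1 (`COc1cc(OC)c(/C=C/S(=O)(=O)Nc2ccc(OC)c(O)c2)c(OC)c1`) gives 30 nM and compound 2 (`COc1cc(OC)c(/C=C/S(=O)(=O)Nc2ccc(OC)c(NC(C)(C)C(=O)O)c2)c(OC)c1`) gives 70 nM. Compound 2 therefore holds the higher of the two numbers and is the weaker inhibitor of the pair. Compound 3 (`COc1cc(OC)c(/C=C/S(=O)(=O)Nc2ccc(OC)c(NC(C(=O)O)c3ccccc3)c2)c(OC)c1`) keeps the core of compound 2 but carries carboxy(phenyl)methyl in place of 1-carboxy-1-methylethyl on a nitrogen on an aromatic ring. Within the data shown here, only one measured step bears on this change, and it does so indirectly. Replacing hydroxy with (1-carboxy-1-methylethyl)amino gave a 2.3-fold higher number from compound 1 to compound 2 (0.37 log units; beyond the scatter), a modest loss. Among the measured compounds shown here, no measured compound shows what a change in the group on this nitrogen does, and none carries the added phenyl ring. The size of that one step, taken from compound 1 to compound 2 as a 2.3-fold higher number from compound 1 to compound 2 (0.37 log units; beyond the scatter), suggests a small effect, with any shift more likely towards a higher number. The expected change is a 1.4-fold higher number from compound 2 to compound 3 (0.15 log units; within the scatter). For compound 3 the estimated value is 100 nM, with an expected range from 30 nM to 350 nM.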

Compound 3, half-maximal inhibitory concentration in the DU-145 assay: 75 nM
Estimate against measurement, compound 3: 1.3-fold (0.12 log units) above; the range from low to high includes it.
By their numbers in the DU-145 assay, from the lowest: compound 1; then compounds 2 and 3 (each within the scatter of the next).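

In the DU-145 assay the swap on this nitrogen gave a 1.1-fold higher number from compound 2 to compound 3 (0.03 log units; within the scatter) and in a physicochemical assay for solubility (a higher number here means a more soluble compound, a lower number a less soluble compound), it gave no change at the digits printed from compound 2 to compound 3 (within the scatter) with compound 2 at 10000 ug/mL and compound 3 at 10000 ug/mL so the carboxy(phenyl)methyl group, with its six-membered aromatic ring of carbon only, leaves both read-outs where 1-carboxy-1-methylethyl had them. Among these compounds, in the DU-145 assay the replacement of hydroxy with (carboxy(phenyl)methyl)amino gave a 2.5-fold higher number from compound 1 to compound 3 (0.40 log units; beyond the scatter) so the modest loss seen with the first group on nitrogen is seen again with the second, and the larger group on the nitrogen brings no recovery towards compound 1. No measurement is available that accounts for this lack of change on the nitrogen.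

Every group shown on this nitrogen keeps its carboxylic acid, so what a methyl ester or a primary amide would do in that place remains open. Also open, going by these compounds, is how a longer chain between the nitrogen and the phenyl ring, or a methoxy or fluoro substituent on that phenyl ring, would read in these two assays.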